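Ethyl for methyl on an ester: does it matter?

A few compounds are considered here, and "the series" means these few. Any claim that something is new, unique, unknown or untested is made for them only; others in the source may bear on it.

Measured so far:
compound 1, `COC/C=C/c1cccc(N(Cc2ccc(/C=C/C(=O)OC(C)(C)C)cc2)C(=O)C2CCCCC2)c1`, 243 nM
compound 2, `CCOC/C=C/c1cccc(N(Cc2ccc(/C=C/C(=O)OC(C)(C)C)cc2)C(=O)C2CCCCC2)c1`, 220 nM
compound 3, `COC(=O)/C=C/c1ccc(CN(C(=O)C2CCCCC2)c2cccc(/C=C/C(=O)OC)c2)cc1`, > 1000 nM

All three were tested in an assay on isolated protein with Bile acid receptor (Homo sapiens) as the target; a lower number here means that less compound is needed, a higher number that more compound is needed for the effect. Compound 1 and compound 2 share one core and differ only where (methyl in place of hydrogen on a saturated chain carbon bound to an oxygen on a saturated carbon). That step, a 1.1-fold lower number from compound 1 to compound 2 (0.04 log units; within the scatter), shows no meaningful shift. Compound 3 has a different core, and the difference between the two cores is not broken down here. For compound 3 the value of > 1000 nM is a limit of this assay, not a number, as the limit of > 1000 nM in this assay, at which 1 of the 3 values shown sits, records.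

The unmeasured compound 4, `CCOC(=O)/C=C/c1ccc(CN(C(=O)C2CCCCC2)c2cccc(/C=C/C(=O)OC)c2)cc1`, stands to compound 3 as compound 2 stands to compound 1: methyl in place of hydrogen on a saturated chain carbon bound to an oxygen next to a carbonyl group. It is the same kind of change, though the surroundings differ: in compound 2 the carbon is bound to an oxygen on a saturated carbon, whereas in compound 4 it is bound to an oxygen next to a carbonyl group. Since the like step from compound 1 to compound 2 was a 1.1-fold lower number from compound 1 to compound 2 (0.04 log units; within the scatter), the step from compound 3 to compound 4 is expected to be small as well, about a step that the limit leaves unreadable from compound 3 to compound 4. Compound 4 is therefore estimated at 1500 nM, with a range of 500 nM to 5000 nM, and most likely this assay again reports only a limit.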

Compound 4, half-maximal effective concentration: > 1000 nM
Compound 4 was reported as a limit; the forecaster's own chance of this, stated with the estimate: 70%; the middle value is on the limit's open side.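

In this assay compound 3 and compound 4 are both reported only as limits, not as numbers, so the step between them cannot be read. The compounds shown leave open what actual number either compound has, and whether methoxycarbonyl to ethoxycarbonyl changes that number at all on this core.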